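Ring swap on the triple-bonded carbon of compound 3

The compounds below may be only part of what the source reports. "The series", "measured", "known", "first", "only" and "open" are said of these compounds alone.

Working notes on the series. In an assay on Sf9 cells for inhibition of mitogen-activated protein kinase kinase kinase 14 variant S549D (Homo sapiens), with a stated time of 30 min, in the presence of a further agent that is not named here (on this read-out lower numbers stand for stronger inhibition and higher numbers for weaker inhibition), compound 1 `C=CC(=O)NCCCc1ccc2ncn(-c3ccnc(N)n3)c2c1` gives 501000 nM. In this assay compound 2 `CC(=O)NCCCCc1ccc2ncn(-c3ccnc(N)n3)c2c1` gives 398000 nM. For the measured compounds named here, the only measured step, a 1.3-fold lower number from compound 1 to compound 2 (0.10 log units; within the scatter), concerns a saturated chain and is within the scatter, so it says nothing about changes on an aromatic ring attached through a triple bond. In this assay, going by the values given here, compound 3 `C=Cc1ccnc(C#Cc2ccc3ncn(-c4ccnc(N)n4)c3c2)c1` gives 1580 nM, the lowest of the three numbers; compound 2 is the nearest and compound 1 the furthest, both far beyond the scatter, and compound 3 is the only measured compound with a triple bond outside aromatic rings.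

Compound 4 `C#Cc1cncc(C#Cc2ccc3ncn(-c4ccnc(N)n4)c3c2)n1` differs from compound 3 by a group of 8 heavy atoms (6 carbon, 2 nitrogen; one six-membered aromatic ring with 2 hetero atoms) in place of a group of 8 heavy atoms (7 carbon, 1 nitrogen; one six-membered aromatic ring with 1 hetero atom), on a triple-bonded carbon. Among the compounds with values here, no measured step bears on a change of this kind, so no step beyond the scatter is expected in this assay in either direction, and the uncertainty is wide. Compound 4 is expected to give about 2000 nM, with a range from 500 nM to 8000 nM. The step this estimate means, a 1.3-fold higher number from compound 3 to compound 4 (0.10 log units; within the scatter), is expected to stay within the scatter.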

Compound 4, half-maximal inhibitory concentration: 6310 nM
Estimate against measurement, compound 4: 3.2-fold (0.50 log units) below, and the stated range covers the measured number.
By their numbers in this assay, from the lowest: compound 3; then compound 4; then compounds 2 and 1 (each within the scatter of the next).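

For the compounds shown here, the ring swap on a triple-bonded carbon gives a 4.0-fold higher number from compound 3 to compound 4 (0.60 log units; beyond the scatter) in this assay and is the first step between two closely related compounds to lie beyond the scatter, so the group carried at this place does change the number. The change is a joint one: one six-membered aromatic ring with 1 hetero atom and a double bond outside aromatic rings leave, and one six-membered aromatic ring with 2 hetero atoms and a triple bond outside aromatic rings enter. No supporting data are available to explain this step.

The compounds shown do not separate the contribution of the ring from that of the unsaturated group on it. Going by these compounds, how an amine, a carboxylic acid or a longer chain on this ring would read in this assay remains open.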